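The source may hold more compounds than are shown below. What is called first, only, known or untested is meant among the compounds shown, and "the series" means these compounds.

Compound 1 `Fc1ccc(-c2nn3c(NC4CCCC4)cccc3c2-c2ccnc(NC3CCCC3)n2)cc1` and compound 2 `COc1ccc(-c2nn3c(NC4CCCC4)cccc3c2-c2ccnc(NC3CCCC3)n2)cc1` share one core, and compound 3 `CSc1cc(NC2CCCC2)cc2c(-c3ccnc(NC4CCCC4)n3)c(-c3ccc(F)cc3)nn12` carries a different core; the difference between the two cores is not broken down here. In an ADME assay on Vero cells (Chlorocebus sabaeus) for cytotoxicity (on this read-out higher numbers stand for lower toxicity in this test and lower numbers for higher toxicity in this test), compound 1 gives only a limit of the test, > 160000 nM. In this assay compound 2 likewise gives only a limit, > 100000 nM. The change from compound 1 to compound 2, (methoxy in place of fluoro on an aromatic carbon), therefore yields a step that the two limits leave unreadable from compound 1 to compound 2, since both values sit at limits (the limit of > 160000 nM in this assay, at which 1 of the 3 values shown sits, and (the limit of > 100000 nM in this assay, at which 1 of the 3 values shown sits)). In this assay compound 3 also gives only a limit, > 40000 nM. Compound 4 `COc1ccc(-c2nn3c(SC)cc(NC4CCCC4)cc3c2-c2ccnc(NC3CCCC3)n2)cc1`, not yet measured, differs from compound 3 by the same change, (methoxy in place of fluoro on an aromatic carbon). Because the measured pair showed a step that the two limits leave unreadable from compound 1 to compound 2, the step from compound 3 to compound 4 is expected to be a step that the limit leaves unreadable from compound 3 to compound 4 in this assay, and most likely another limit. In this assay compound 4 is therefore estimated at 80000 nM, with a range from 30000 nM to 200000 nM.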

Compound 4, half-maximal cytotoxic concentration: > 40000 nM
Compound 4 ended at the assay's limit; the forecaster's own chance of this, stated with the estimate: 70%; the middle value lies beyond the limit too.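

Compound 3 and compound 4 both end at a limit in this assay, so no size can be read for the change from 4-fluorophenyl to 4-methoxyphenyl, and the same holds for compound 1 and compound 2. The compounds shown leave open whether this change alters the read-out at all, and at what concentration any of the four would become toxic to these cells.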